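Working notes on compound 2 and the proposed compound 3

The source may hold more compounds than are shown below. What is called first, only, known or untested is meant among the compounds shown, and "the series" means these compounds.

The measured values in a functional assay on the whole organism with Mus musculus as the target (on this read-out lower numbers stand for an effect already at smaller amounts and higher numbers for an effect only at larger amounts of compound), are both limits. In this assay compound 1 `CNCc1nnc(-c2ccccc2)s1` shows > 200 mg/kg, a limit of the assay and not a number. In this assay compound 2 `Cc1ccccc1NCc1nnc(-c2ccccc2-c2ccccc2)s1` likewise stops at > 200 mg/kg, again a limit rather than a number. For the measured compounds named here, compound 2 thus stands at the limit of > 200 mg/kg in this assay, at which 2 of the 2 values shown sit; no step between measured compounds is known. Compound 3 `NCCCc1nnc(-c2ccccc2-c2ccccc2)s1` is not yet measured in this assay. The change from compound 2 is 2-aminoethyl in place of (2-methylphenyl)amino on a saturated chain carbon bound to an aromatic carbon. Going by the values given here, with no measured step to rest on, the expected step from compound 2 to compound 3 is a step that the limit leaves unreadable from compound 2 to compound 3, meaning no change beyond the scatter, and this assay will most likely again report only a limit. Compound 3 is therefore estimated at about 300 mg/kg, within 100 mg/kg to 1000 mg/kg.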

Compound 3, dose for half-maximal effect: > 200 mg/kg
Compound 3 gave a limit, no number; the forecaster's own chance of this, stated with the estimate: 75%; the middle value lies beyond the limit too.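

No step from compound 2 to compound 3 can be read in this assay, since both values are limits and not numbers: the limit of > 200 mg/kg in this assay, at which 3 of the 3 values shown sit.

The compounds shown leave open what number any of them would reach in this assay, and whether 2-aminoethyl in place of (2-methylphenyl)amino changes it at all.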